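Adding a Methoxy Group to a Hydroxamic Acid Series

The source may hold more compounds than are shown below. What is called first, only, known or untested is meant among the compounds shown, and "the series" means these compounds.

Compound 1 `O=C(/C=C/c1ccc(/C=C/C(=O)c2cc(Cl)ccc2Cl)o1)NO` gives 4310 nM
Compound 2 `O=C(/C=C/c1ccc(/C=C/C(=O)c2ccc3ccccc3c2)o1)NO` gives 4380 nM
Compound 3 `O=C(/C=C/c1ccc(/C=C/C(=O)c2ccc(Cl)cc2)o1)NO` gives 6030 nM

All three compounds share the same core and were tested in an assay on isolated protein for inhibition of histone deacetylase 4 (Homo sapiens), read by fluorescence; on this read-out higher numbers stand for weaker inhibition and lower numbers for stronger inhibition. Compound 2 has the second highest of the three numbers. Its nearest neighbour is compound 1, whose value lies within the scatter of compound 2, and its furthest is compound 3, which also lies within the scatter. On these three numbers there is therefore no difference that can be read as real: the compounds behave alike in this assay.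

Compound 4 `COc1ccc2cc(C(=O)/C=C/c3ccc(/C=C/C(=O)NO)o3)ccc2c1` is the next compound and has not yet been measured. It differs from compound 2 in one place: methoxy in place of hydrogen on an aromatic carbon.

Among the compounds with values here, no pair of measured compounds differs in a single place, so the data give no direct guide to what this kind of change does here. The three measured compounds, which differ from one another in larger ways, still fall within the scatter of each other. On that basis the step expected from compound 2 to compound 4 in this assay is a 1.0-fold higher number from compound 2 to compound 4 (0.00 log units; within the scatter), a step no larger than the scatter, in no particular direction. Compound 4 is accordingly estimated at 4400 nM, with a range from 2000 nM to 10000 nM.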

Compound 4, half-maximal inhibitory concentration: 4040 nM
Beside the measured number, compound 4's estimate is 1.1-fold (0.04 log units) above it; low and high end bracket the measured number.
By their numbers in this assay, from the lowest: compounds 4, 1, 2 and 3 (each within the scatter of the next).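

In this assay the pair of compound 2 and compound 4, the first here that differs in one place only, shows a 1.1-fold lower number from compound 2 to compound 4 (0.04 log units; within the scatter) and so gives a direct reading of this change. Methoxy in place of hydrogen on this aromatic carbon, on a six-membered ring that is part of a fused system of two rings, leaves no difference that can be told apart from the ordinary spread of repeated measurements, something the earlier compounds, which differ from one another in larger ways, could only hint at. No measurement at hand explains this result.

This single step says nothing about whether other groups on the same carbon, such as an amine, a carboxylic acid or a longer alkoxy chain, would also leave the number where it is. It also leaves open whether methoxy would behave the same way on another carbon of this ring system, or on the chlorine-bearing rings of compound 1 and compound 3.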